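A few compounds are considered here, and "the series" means these few. Any claim that something is new, unique, unknown or untested is made for them only; others in the source may bear on it.

Of the compounds shown here, three share one core and have been tested for how much of them cells tolerate. Compound 1 `CC(C)n1nc(C(=O)N[C@H]2COc3ccccc3N(C)C2=S)nc1Cc1ccccc1` is examined in a toxicity assay on HT-29 cells (Homo sapiens) for cytotoxicity; a higher number here means that more compound is tolerated, a lower number that less compound is tolerated; compound 1 reaches only a limit of the assay, > 100000 nM. Compound 2 `COCCn1nc(C(=O)N[C@H]2COc3ccccc3N(C)C2=S)nc1Cc1ccccc1` likewise gives only a limit in this assay, > 100000 nM. Compound 3 `CN1C(=S)[C@@H](NC(=O)c2nc(Cc3ccccc3)n(CCCCCC#N)n2)COc2ccccc21` also stops at a limit in this assay, > 100000 nM. The steps a step that the two limits leave unreadable from compound 1 to compound 2, a step that the two limits leave unreadable from compound 1 to compound 3 and a step that the two limits leave unreadable from compound 2 to compound 3 therefore cannot be read, since (the limit of > 100000 nM in this assay, at which 3 of the 3 values shown sit). Compound 4 `CN1C(=S)[C@@H](NC(=O)c2nc(Cc3ccccc3)n(C3CCOCC3)n2)COc2ccccc21` is not yet measured; it differs from compound 2 by oxan-4-yl in place of 2-methoxyethyl on an aromatic nitrogen. Among the measured compounds shown here, no measured step bears readably on this change, so nothing points to a direction. It is expected that compound 4 again sits at the limit, with an estimated value of 150000 nM in a range from 50000 nM to 400000 nM. The expected step is a step that the limit leaves unreadable from compound 2 to compound 4.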

Compound 4, half-maximal cytotoxic concentration: > 100000 nM
Compound 4: no number, only a limit; the forecaster's own chance of this, stated with the estimate: 85%; the middle value is on the limit's open side.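

Among the compounds shown here, no step among compound 1, compound 2, compound 3 and compound 4 can be read, because each stops at a limit: the limit of > 100000 nM in this assay, at which 4 of the 4 values shown sit. As far as these compounds go, whether the group on the aromatic nitrogen changes the outcome in this assay at all stays open.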